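The source may hold more compounds than are shown below. What is called first, only, known or untested is meant among the compounds shown, and "the series" means these compounds.

Measured so far in an ADME assay on MT4 cells (Homo sapiens) for cytotoxicity; on this read-out higher numbers stand for lower toxicity in this test and lower numbers for higher toxicity in this test:

- Compound 1 `Cc1cc(C)cc(S(=O)(=O)n2c(SCC(=O)Nc3ccccc3Cl)nc3ccc(Cl)cc32)c1`: 99300 nM
- Compound 2 `Cc1cc(C)cc(S(=O)(=O)n2c(SCC(=O)Nc3ccccc3Br)nc3ccc(Cl)cc32)c1`: 145000 nM
- Compound 3 `Cc1cc(C)cc(Cn2c(SCC(=O)Nc3ccc(S(N)(=O)=O)cc3Cl)nc3ccc(Cl)cc32)c1`: >= 18500 nM

From the compounds shown here alone, the entry for compound 3 is a limit of the assay and not a number, so its true position on the scale stays open. Compound 4 `Cc1cc(C)cc(S(=O)(=O)n2c(SCC(=O)Nc3ccc(S(N)(=O)=O)cc3Cl)nc3ccc(Cl)cc32)c1` is the next to be read in this assay. It differs from compound 3 in one place, on an aromatic nitrogen: (3,5-dimethylphenyl)sulfonyl in place of 3,5-dimethylbenzyl on an aromatic nitrogen.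

Going by the values given here, no measured step covers this exchange. The only one available, a 1.5-fold higher number from compound 1 to compound 2 (0.16 log units; within the scatter), is a swap of bromo for chloro on an aromatic carbon elsewhere in the molecule, so it says little about the change at hand. More useful are the values themselves. Compound 1 gives 99300 nM and compound 2 gives 145000 nM, and both carry the same (3,5-dimethylphenyl)sulfonyl as compound 4, though they differ from it elsewhere. On that basis a number somewhat higher than the limit of compound 3 is expected, and a limit may well be reported again. Counted from that limit, the estimated step is a step that the limit leaves unreadable from compound 3 to compound 4. The estimated value for compound 4 is 60000 nM, within an expected range of 20000 nM to 180000 nM.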

Compound 4, half-maximal cytotoxic concentration: 23400 nM
Compound 4: the middle estimate sits 2.6-fold (0.41 log units) above what was measured; low and high end bracket the measured number.
By their numbers in this assay, from the lowest: compound 4; then compounds 1 and 2 (each within the scatter of the next).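

In this assay, the entry for compound 3 is a limit of the assay and not a number, so the step to compound 4, with (3,5-dimethylphenyl)sulfonyl in place of 3,5-dimethylbenzyl on the aromatic nitrogen, cannot be read: the limit of >= 18500 nM in this assay, at which 1 of the 4 values shown sits.

Going by these compounds alone, the new value speaks instead to the other end of the molecule, where the earlier compounds offered only an exchange of halogens, a 1.5-fold higher number from compound 1 to compound 2 (0.16 log units; within the scatter). With (3,5-dimethylphenyl)sulfonyl present on both sides of the comparison, sulfamoyl in place of hydrogen on an aromatic carbon gives a 4.2-fold lower number from compound 1 to compound 4 (0.63 log units; beyond the scatter), and 2-chloro-4-sulfamoylphenyl in place of 2-bromophenyl on the amide-type nitrogen gives a 6.2-fold lower number from compound 2 to compound 4 (0.79 log units; beyond the scatter). Both steps lie beyond the scatter and point towards higher toxicity in this test, though both remain modest.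

From the compounds shown here alone, whether the aromatic nitrogen matters at all for this read-out stays open, and so does how a benzoyl group in that place would read. Going by these compounds, it is equally open whether a carboxylic acid or an amine in place of sulfamoyl would lower the number in this assay by a similar step.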